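From 3,5-Dimethylphenyl to 3-Methoxyphenyl on the Ring Amine

A few compounds are considered here, and "the series" means these few. Any claim that something is new, unique, unknown or untested is made for them only; others in the source may bear on it.

Three compounds sharing one core have been characterised in a functional assay on HL-60 cells (Homo sapiens) for inhibition, read by MTT assay, with a stated time of 72 h; on this read-out higher numbers stand for weaker inhibition and lower numbers for stronger inhibition. Compound 1 `CC(=O)c1ccc(N2CCN(C(=O)c3oc(C)nc3-c3ccccc3)CC2)cc1` is recorded as "not active" (no number reported) in this assay. Compound 2 `Cc1nc(-c2ccccc2)c(C(=O)N2CCN(c3cccc(F)c3)CC2)o1` gives 45 nM in this assay. Compound 3 `Cc1cc(C)cc(N2CCN(C(=O)c3oc(C)nc3-c3ccccc3)CC2)c1` gives 34.5 nM in this assay, the lowest of the two numbers available, though its gap to compound 2 stays within the scatter: a 1.3-fold lower number from compound 2 to compound 3 (0.12 log units; within the scatter). No ordering between compound 2 and compound 3 can therefore be claimed.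

Compound 4 `COc1cccc(N2CCN(C(=O)c3oc(C)nc3-c3ccccc3)CC2)c1` has not yet been measured. It differs from compound 3 at one place only: 3-methoxyphenyl in place of 3,5-dimethylphenyl on an amine nitrogen in a ring. This is the same site that changed between compound 2 and compound 3, and that step was small. Among the measured compounds shown here, the only precedent thus suggests that swapping one aryl substituent for another on the amine nitrogen in the ring leaves the number close to where it was, with no evidence for a shift beyond the scatter in either direction.

Compound 4 is accordingly estimated at 40 nM in this assay, with a range from 15 nM to 120 nM. The step this implies, a 1.2-fold higher number from compound 3 to compound 4 (0.06 log units; within the scatter), is expected to remain within the usual scatter.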

Compound 4, half-maximal inhibitory concentration: 34.8 nM
The estimate for compound 4 lay 1.1-fold (0.06 log units) above the measured number, and the stated range covers the measured number.
By their numbers in this assay, from the lowest: compounds 3, 4 and 2 (each within the scatter of the next).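

In this assay, the exchange of 3,5-dimethylphenyl for 3-methoxyphenyl on the ring amine nitrogen gives a 1.0-fold higher number from compound 3 to compound 4 (0.00 log units; within the scatter), so a group with a hydrogen-bond acceptor, where the departing group has none, leaves the number where it was within the scatter. The direct comparison of the two single substituents, with methoxy in place of fluoro on an aromatic carbon, gives a 1.3-fold lower number from compound 2 to compound 4 (0.11 log units; within the scatter), which adds a second step of the same small size at this position. Compound 2, compound 3 and compound 4 therefore cannot be ordered, and the one entry that goes against this flat picture is compound 1, whose phenyl carries an acetyl group and which is recorded as "not active" (no number reported) without a number that could be set beside theirs.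

No independent measurement bears on these results or on the contrast with compound 1. The compounds shown leave open whether this flat picture would hold for a phenyl ring carrying an amine, a carboxylic acid or a longer alkoxy chain such as butoxy, and whether other carbonyl-bearing groups, such as an ester, would behave like the acetyl group of compound 1.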